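A few compounds are considered here, and "the series" means these few. Any claim that something is new, unique, unknown or untested is made for them only; others in the source may bear on it.

Two analogues sharing one core were tested in a functional assay on PANC-1 cells (Homo sapiens) for inhibition, read by MTT assay, with a stated time of 24 h, tested at 10 uM; on this read-out lower numbers stand for less inhibition and higher numbers for more inhibition at the one concentration tested (going by the name of the read-out). Compound 1, `CC(C)=CCC1Cc2c(OC(=O)Nc3ccc(F)cc3F)cc(=O)n(CCCO)c2CC1(C)C`, carries a ((2,4-difluorophenyl)carbamoyl)oxy group; in this assay compound 1 gives 0%. Compound 2, `COc1cccc(NC(=O)Oc2cc(=O)n(CCCO)c3c2CC(C/C=C(\C)CCC=C(C)C)C(C)(C)C3)c1`, carries a ((3-methoxyphenyl)carbamoyl)oxy group; in this assay compound 2 gives 11.3%. Compound 2 therefore stands highest of the two numbers, its nearest neighbour being compound 1, which lies lower by an amount beyond the usual scatter.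

The next compound, compound 3, `CC(C)=CCC/C(C)=C/CC1Cc2c(OC(=O)Nc3ccc(F)cc3F)cc(=O)n(CCCO)c2CC1(C)C`, has not yet been measured. It differs from compound 2 in one place: 2,4-difluorophenyl in place of 3-methoxyphenyl on an amide-type nitrogen. Going by the values given here, since compound 1, the only measured compound bearing the (2,4-difluorophenyl)carbamoyl group, gives 0%, a small step downward, or none beyond the scatter, is expected from compound 2 to compound 3, estimated as a number 6.3 percentage points lower from compound 2 to compound 3 (within the scatter). Compound 3 is accordingly expected to give about 5%, within a range from 0% to 15%.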

Compound 3, a percentage reported as inhibition, at one concentration (the size of the read-out at that concentration, not a potency): 15.6%
Beside the measured number, compound 3's estimate is 10.6 percentage points below it, outside the stated range (above it).
By their numbers in this assay, from the lowest: compound 1; then compounds 2 and 3 (each within the scatter of the next).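

In this assay, 2,4-difluorophenyl in place of 3-methoxyphenyl on the amide-type nitrogen gives a number 4.3 percentage points higher from compound 2 to compound 3 (within the scatter), so with the chain shared by compound 2 and compound 3, this change does not separate the two compounds. With the (2,4-difluorophenyl)carbamoyl group held fixed, 3-methylbut-2-en-1-yl in place of hydrogen on a saturated chain carbon bound to a double-bonded chain carbon gives a number 15.6 percentage points higher from compound 1 to compound 3 (beyond the scatter), so the low number of compound 1 does not follow from that carbamoyl group alone. No evidence given here accounts for either step.

Going by these compounds, it remains open whether a 4-aminophenyl group on the amide-type nitrogen, or a chain longer than that of compound 3, would move the number beyond the scatter. Also open, on these data alone, is how the 3-methoxyphenyl group would read alongside the chain of compound 1.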